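A few compounds are considered here, and "the series" means these few. Any claim that something is new, unique, unknown or untested is made for them only; others in the source may bear on it.

Measured so far:
compound 1, `CNC(=O)N1CCCc2ccc(NC(=O)c3ccc(-c4cc[nH]n4)cc3)cc21`, gives 92.5% in a functional assay on MV4-11 cells (Homo sapiens) for antiproliferative activity, with a stated time of 6 days, tested at 1.56 uM; on this read-out higher numbers stand for a stronger effect at the one concentration tested and lower numbers for a weaker effect
compound 2, `CNC(=O)N1CCCc2ccc(NC(=O)c3ccc(-c4ccn(S(C)(=O)=O)n4)cc3)cc21`, gives 8.81% in this assay

Among the measured compounds shown here, compound 2 stands at the lower of these two numbers, and the only measured step leads down to it: a number 83.7 percentage points lower from compound 1 to compound 2 (beyond the scatter), a large loss once the hydrogen on the aromatic nitrogen is replaced. Compound 3, `CNC(=O)N1CCCc2ccc(NC(=O)c3ccc(-c4ccccn4)cc3)cc21`, is not yet measured; compared with compound 2 the change is pyridin-2-yl in place of 1-(methylsulfonyl)-1H-pyrazol-3-yl on an aromatic carbon. The step into compound 2 bears on this only indirectly, since compound 3 keeps neither the hydrogen of compound 1 nor the methylsulfonyl of compound 2 but brings a different ring altogether. The whole of the measured range lies between the two known values, so a step back upward is expected, though of uncertain size: a number 41.2 percentage points higher from compound 2 to compound 3 (beyond the scatter) is the expected change. Compound 3 is estimated at 50%, with a range from 15% to 85%.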

Compound 3, a percentage reported as inhibition, at one concentration (the size of the read-out at that concentration, not a potency): 32%
Compound 3: middle estimate off by 18 percentage points, on the high side; the measured number falls inside the stated range.
By their numbers in this assay, from the lowest: compound 2; then compound 3; then compound 1.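

Compound 3 shows that a pyridin-2-yl ring on this aromatic carbon, para to a large group, keeps part of the effect in this assay: in place of the 1-(methylsulfonyl)-1H-pyrazol-3-yl group it gives a number 23.2 percentage points higher from compound 2 to compound 3 (beyond the scatter). The same ring in place of the 1H-pyrazol-3-yl group gives a number 60.5 percentage points lower from compound 1 to compound 3 (beyond the scatter), so the loss at this position is not tied to the methylsulfonyl group alone, and the unsubstituted pyrazole remains the best of the three. Nothing available explains these differences.

The compounds shown leave open whether the hydrogen on the pyrazole nitrogen is itself what matters, or simply the pyrazole ring. A small group such as methyl on that nitrogen, or an amine on the pyridine ring, would bear on this question.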